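The source may hold more compounds than are shown below. What is called first, only, known or untested is meant among the compounds shown, and "the series" means these compounds.

In a functional assay, read by spectrophotometry, with a stated time of 5 min (on this read-out lower numbers stand for stronger inhibition and higher numbers for weaker inhibition), compound 1 (`COc1cc(/C=C/C(=O)C(=Cc2ccc(OC)c(OC)c2)C(=O)/C=C/c2ccc(O)c(OC)c2)ccc1O`) gives 71000000 nM and compound 2 (`COc1cc(/C=C/C(=O)C(=Cc2ccc(O)cc2)C(=O)/C=C/c2ccc(O)c(OC)c2)ccc1O`) gives 48700000 nM while compound 3 (`CCOc1cc(C=C(C(=O)/C=C/c2ccc(O)c(OCC)c2)C(=O)/C=C/c2ccc(O)c(OCC)c2)ccc1O`) gives 96700000 nM and so lies within the scatter of both. Compound 4 (`CCOc1cc(/C=C/C(=O)C(=Cc2ccc(OCC)c(OCC)c2)C(=O)/C=C/c2ccc(O)c(OCC)c2)ccc1O`) differs from compound 3 by ethyl in place of hydrogen on an oxygen on an aromatic ring, turning 3-ethoxy-4-hydroxyphenyl into 3,4-diethoxyphenyl. Among the compounds with values here, the one measured step that bears on this change exchanges 3,4-dimethoxyphenyl for 4-hydroxyphenyl and shows a 1.5-fold lower number from compound 1 to compound 2 (0.16 log units; within the scatter) so it offers no sign of a real shift. No shift beyond the scatter is therefore expected in this assay in either direction, and the expected step is a 1.0-fold higher number from compound 3 to compound 4 (0.01 log units; within the scatter) (an estimate). Compound 4 is estimated at 100000000 nM (expected range 50000000 nM to 200000000 nM).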

Compound 4, half-maximal inhibitory concentration: 61600000 nM
Estimate against measurement, compound 4: 1.6-fold (0.21 log units) above; the measured number falls inside the stated range.
By their numbers in this assay, from the lowest: compounds 2, 4, 1 and 3 (each within the scatter of the next).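

In this assay, within the data shown here, turning 3-ethoxy-4-hydroxyphenyl into 3,4-diethoxyphenyl gives a 1.6-fold lower number from compound 3 to compound 4 (0.20 log units; within the scatter) and is the first direct reading of ethyl in place of hydrogen on an oxygen on an aromatic ring. It shows that this hydrogen can give way to ethyl with no shift beyond the scatter. No evidence bearing on why this is so is available. Going by these compounds, whether an amine or a carboxylic acid at the end of a longer chain on this oxygen would move the number beyond the scatter in this assay remains open.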